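Removing One Fluoro Group: an Expected Shift in Inhibition

The compounds below may be only part of what the source reports. "The series", "measured", "known", "first", "only" and "open" are said of these compounds alone.

Of the compounds shown here, three have been measured in an assay on isolated protein for inhibition of alkaline phosphatase, tissue-nonspecific isozyme (Homo sapiens); on this read-out lower numbers stand for stronger inhibition and higher numbers for weaker inhibition. Compound 1 `O=C(c1cc(-c2ccc(Cl)cc2Cl)n[nH]1)N(CCO)CCO` gives 47 nM, compound 2 `O=C(c1cc(-c2cc(F)c(Cl)cc2Cl)n[nH]1)N(CCO)CCO` gives 127 nM, and compound 3 `O=C(NCCO)c1cc(-c2cc(F)c(F)cc2F)n[nH]1` gives 134 nM. The change from compound 2 to compound 1 is hydrogen in place of fluoro on an aromatic carbon, and it made a 2.7-fold lower number from compound 2 to compound 1 (0.43 log units; beyond the scatter). Compound 3 and compound 2 differ in more than one place, and the difference between the two cores is not broken down here; their values in this assay lie within the usual scatter of each other.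

Compound 4 `O=C(NCCO)c1cc(-c2ccc(F)cc2F)n[nH]1` has not yet been measured. It differs from compound 3 by hydrogen in place of fluoro on an aromatic carbon. Within the data shown here, this is the same kind of change as the one from compound 2 to compound 1, but the surroundings differ: there the carbon was ortho to a chloro group and para to a chloro group, here it is ortho to a fluoro group and para to a fluoro group. Resting on the step already seen from compound 2 to compound 1, compound 4 is expected to show a step of a 2.2-fold lower number from compound 3 to compound 4 (0.35 log units; beyond the scatter) in this assay. Compound 4 is therefore estimated at 60 nM in this assay, most likely between 25 nM and 160 nM.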

Compound 4, half-maximal inhibitory concentration: 35 nM
Compound 4: middle estimate off by 1.7-fold (0.23 log units), on the high side, within the range that was stated.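

In this assay, hydrogen in place of the fluoro group gave a 3.8-fold lower number from compound 3 to compound 4 (0.58 log units; beyond the scatter), so the change moved the number in the same direction on the core of compound 3 as it did on the core of compound 2. Among these compounds, the size of the step also carried over between the two cores: the same change on two cores in this assay, a 2.7-fold lower number (0.43 log units; beyond the scatter) from compound 2 to compound 1 and a 3.8-fold lower number (0.58 log units; beyond the scatter) from compound 3 to compound 4, 1.4-fold (0.15 log units) apart, within the scatter of two such steps This rests on only two pairs, however, and it shows neither that the step would hold on a core outside these two nor why the number falls.

The compounds shown leave open whether a methyl or methoxy group in that same place would give a number closer to that of the hydrogen or the fluoro compound, and whether a chloro group there would behave like the fluoro group. Also open, as far as these compounds go, is whether the step would survive if the chain on the amide gave way to a longer chain or to one ending in a carboxylic acid.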